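From 4-Bromo-2-fluorophenyl to 3-Methoxyphenyl on the Amide

The source may hold more compounds than are shown below. What is called first, only, known or untested is meant among the compounds shown, and "the series" means these compounds.

In a functional assay on CCRF-CEM cells (Homo sapiens) for cytotoxicity, with a stated time of 20 h (a lower number here means that less compound is tolerated, a higher number that more compound is tolerated), compound 1 (`Cc1ccc(NC(=O)COc2ccc3cc(/C=C4/SC(=O)NC4=O)ccc3c2)cc1`) gives 2800 nM and compound 2 (`O=C(COc1ccc2cc(/C=C3/SC(=O)NC3=O)ccc2c1)Nc1ccc(Br)cc1F`) gives 40900 nM as the higher of the two numbers. For the measured compounds named here, the single measured step (a 15-fold higher number from compound 1 to compound 2 (1.16 log units; beyond the scatter)) is large and lies beyond the scatter. It put 4-bromo-2-fluorophenyl in place of 4-methylphenyl on an amide-type nitrogen. Compound 3 (`COc1cccc(NC(=O)COc2ccc3cc(/C=C4/SC(=O)NC4=O)ccc3c2)c1`) changes that same group again (3-methoxyphenyl in place of 4-bromo-2-fluorophenyl on an amide-type nitrogen), with 3-methoxyphenyl in place of 4-bromo-2-fluorophenyl. Like compound 1 at 2800 nM it lacks the 4-bromo-2-fluorophenyl group, so a move back towards that lower number seems likely, although one step cannot fix its size. The expected change in this assay is a clear drop beyond the scatter (a 6.8-fold lower number from compound 2 to compound 3 (0.83 log units; beyond the scatter)) and not quite the full size of the other step. Compound 3 is estimated at 6000 nM (range 1500 nM to 25000 nM) on this reasoning.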

Compound 3, half-maximal cytotoxic concentration: 10700 nM
Compound 3: the middle estimate sits 1.8-fold (0.25 log units) below what was measured, within the range that was stated.
By their numbers in this assay, from the lowest: compound 1; then compound 3; then compound 2.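

On an amide-type nitrogen, three different phenyl groups now give three separate levels in this assay and not just a high and a low one. There is a 3.8-fold lower number from compound 2 to compound 3 (0.58 log units; beyond the scatter) and also a 3.8-fold higher number from compound 1 to compound 3 (0.58 log units; beyond the scatter) in the same sentence of results, so 3-methoxyphenyl stands apart from both other groups, each step modest yet beyond the scatter. Nothing available explains this order of the three groups.

Each step swaps a whole group, so the part played by the methoxy group cannot be separated from the part played by where it sits on the ring. A 4-methoxyphenyl group or an unsubstituted phenyl on the same nitrogen would help to separate them, and a pyridine ring or an amine-bearing chain there remains an open question.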